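This account rests on a few compounds, and the source may have more. Where it says the series, first, only, none or still open, it means among the compounds named here.

The series keeps the core seen in compound 1 `CN(c1cccc2c1CN(c1nc(Nc3ccc(Cl)c(C(F)(F)F)c3)ncc1C(F)(F)F)C2)S(C)(=O)=O` and varies the aryl group attached to the amine nitrogen. In a functional assay on OVCAR-3 cells (Homo sapiens) for antiproliferative activity, read by spectrophotometry, with a stated time of 2 days (a lower number here means a stronger inhibitor of growth, a higher number a weaker inhibitor of growth), compound 1 gives > 50000 nM, which is a limit of the assay rather than a number (the limit of > 50000 nM in this assay, at which 1 of the 3 values shown sits). Compound 2 `COc1cc(Nc2ncc(C(F)(F)F)c(N3Cc4cccc(N(C)S(C)(=O)=O)c4C3)n2)cc(OC)c1` gives 630 nM in this assay. Compound 3 `COc1cc(N2CCN(C(C)=O)CC2)ccc1Nc1ncc(C(F)(F)F)c(N2Cc3cccc(N(C)S(C)(=O)=O)c3C2)n1` gives 1600 nM. For the measured compounds named here, the one measured single-point step, an at least 79-fold lower number from compound 1 to compound 2 (1.89 log units; beyond the scatter), leaves compound 2 with the lowest number of the two reported, compound 3 being the nearest to it.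

Compound 4 `Cc1ccc(Nc2ncc(C(F)(F)F)c(N3Cc4cccc(N(C)S(C)(=O)=O)c4C3)n2)cc1C` is not yet measured. It differs from compound 2 by 3,4-dimethylphenyl in place of 3,5-dimethoxyphenyl on a nitrogen on an aromatic ring. Going by the values given here, the only measured step at the same place is an at least 79-fold lower number from compound 1 to compound 2 (1.89 log units; beyond the scatter), which shows that the group on this nitrogen can move the number far beyond the scatter. With 3,4-dimethylphenyl in place of 3,5-dimethoxyphenyl, a weakening is expected, estimated as a 4.0-fold higher number from compound 2 to compound 4 (0.60 log units; beyond the scatter). Compound 4 is therefore expected to give about 2500 nM in this assay, with a range of 600 nM to 15000 nM.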

Compound 4, concentration for 50% growth inhibition: > 30000 nM
Compound 4: only a limit was reported (the forecaster's own chance of this, stated with the estimate: 15%); at least 12-fold (1.07 log units) between middle value and limit.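

In this assay compound 4 gives > 30000 nM, which is a limit of the assay and not a number. The step still reads as an at least 47-fold higher number from compound 2 to compound 4 (1.67 log units; beyond the scatter), so this nitrogen is sensitive not only to the replacement of a halogen-bearing aryl group: a swap between two aryl groups, each a six-membered aromatic ring of carbon only with no net charge, also moves the number far beyond the scatter. The step between compound 1 and compound 4 cannot be read, as both stand at limits.

The change to compound 4 alters both the type of substituent and its arrangement on the ring, and the compounds shown do not separate the two. An unsubstituted phenyl or an aryl group bearing a single methoxy group would help to do so.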